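This account rests on a few compounds, and the source may have more. Where it says the series, first, only, none or still open, it means among the compounds named here.

Compound 1, `c1ccc(CO/N=C2/C(c3c[nH]c4ccccc34)=Nc3ccccc32)cc1`, gives 12200 nM in a functional assay on T-24 cells (Homo sapiens) for cytotoxicity, read by MTT assay, with a stated time of 2 days; on this read-out higher numbers stand for weaker inhibition and lower numbers for stronger inhibition.
Compound 2, `N#Cc1ccc2c(c1)/C(=N\OCc1ccccc1)C(c1c[nH]c3ccc(C#N)cc13)=N2`, gives 18600 nM in this assay.
Compound 3, `Cc1ccc(CO/N=C2/C(c3c[nH]c4ccc(F)cc34)=Nc3ccc(F)cc32)cc1`, gives 20000 nM in this assay.

Among these three, compound 1 has the smallest number, yet the numbers of compound 2 and compound 3 both lie within the scatter of it, so the three cannot be set apart on these data alone. For the measured compounds named here, no pair of the measured compounds differs in only one place, so no single change has yet been tied to a measured step in this assay.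

Compound 4, `Fc1ccc(CO/N=C2/C(c3c[nH]c4ccccc34)=Nc3ccccc32)c(Cl)c1`, is not yet measured. It differs from compound 1 in one place: 2-chloro-4-fluorophenyl in place of phenyl on a saturated chain carbon bound to an oxygen on an unsaturated carbon. The shared core of compound 1 and the benzyloxy oxime are kept, and only the two halogens on the outer ring are new. Going by the values given here, with no measured step of this kind to lean on, and with all three measured numbers sitting close together, the step is expected to be small, a 1.2-fold lower number from compound 1 to compound 4 (0.09 log units; within the scatter), with no clear direction beyond the scatter. Compound 4 is therefore estimated at 10000 nM in this assay, within a range from 4000 nM to 30000 nM.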

Compound 4, half-maximal inhibitory concentration: 20000 nM
Compound 4: the middle estimate sits 2.0-fold (0.30 log units) below what was measured; the measured number falls inside the stated range.
By their numbers in this assay, from the lowest: compounds 1, 2, 3 and 4 (each within the scatter of the next).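

With 2-chloro-4-fluorophenyl in place of phenyl on a saturated chain carbon bound to an oxygen on an unsaturated carbon, this assay now has its first single change tied to a measured step, a 1.6-fold higher number from compound 1 to compound 4 (0.21 log units; within the scatter). This step lies within the scatter, so the outer ring at this place accepts a chlorine and a fluorine with no change that these data can resolve. No measurement at hand offers an explanation for this outcome.

The compounds shown do not separate the share of the chlorine from that of the fluorine, nor do they tell whether the same change would behave alike with the nitrile or fluorine groups carried by compound 2 and compound 3. Going by these compounds, it also remains open whether an amine, a carboxylic acid or a longer chain in place of the benzyl group would move the number beyond the scatter.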